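This account rests on a few compounds, and the source may have more. Where it says the series, first, only, none or still open, it means among the compounds named here.

In an assay on HEK293 cells for displacement of a labelled ligand from 5-hydroxytryptamine receptor 6 (Homo sapiens), with a stated time of 60 min, tested at 1 uM, in the presence of a further agent that is not named here (a lower number here means a weaker effect, a higher number a stronger effect of the compound at the concentration tested), compound 1 `COc1cc(N)c(Cl)cc1C(=O)CCC1CCN(CCNS(=O)(=O)c2cc(Br)ccc2Br)CC1` gives 52%, and compound 2 `COc1ccc(S(=O)(=O)NCCN2CCC(CCC(=O)c3cc(Cl)c(N)cc3OC)CC2)cc1OC` gives 58%. These two numbers lie within the scatter of each other, so compound 2 stands level with compound 1 rather than above it. Compound 3 `COc1cc(N)c(Cl)cc1C(=O)CCC1CCN(CCNS(=O)(=O)c2ccc(NC(C)=O)cc2)CC1` differs from compound 2 by 4-acetamidophenyl in place of 3,4-dimethoxyphenyl on a sulfonyl sulfur. Among the measured compounds shown here, the only measured step bears directly on this, as it also exchanged the ring on the sulfonyl sulfur: a number 6 percentage points higher from compound 1 to compound 2 (within the scatter). On that basis the expected change is a number 6 percentage points lower from compound 2 to compound 3 (within the scatter), nothing beyond the scatter. Compound 3 is therefore estimated at 52%, with a range from 32% to 72%.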

Compound 3, a percentage reported as inhibition, at one concentration (the size of the read-out at that concentration, not a potency): 67%
The estimate for compound 3 lay 15 percentage points below the measured number; the measured number falls inside the stated range.
By their numbers in this assay, from the lowest: compounds 1, 2 and 3 (each within the scatter of the next, the first and the last beyond it).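

In this assay, changing the ring on the sulfonyl sulfur now has a measurable effect: 4-acetamidophenyl in place of 2,5-dibromophenyl gives a number 15 percentage points higher from compound 1 to compound 3 (beyond the scatter), a step the earlier pair did not show. Against 3,4-dimethoxyphenyl, the same group gives a number 9 percentage points higher from compound 2 to compound 3 (within the scatter), so these two rings cannot be told apart. No measurement bears on why the ring matters. Still open, from the compounds shown here alone, is how a plain amine or a carboxylic acid on this ring would compare with the acetamide, and whether a longer acyl chain on its nitrogen would change the read-out.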